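Removing a chloro group from a dopamine D4 antagonist

The source may report more compounds than this note shows. Statements on the series, on what has been measured and on what is new or still open speak of the compounds shown alone.

Measured compounds:
- Compound 1, `Cn1c(CN2CCN(c3ccc(C(F)(F)F)cc3)CC2)nc2ccccc21`: 398 nM
- Compound 2, `Cn1c(CN2CCN(c3ncc(C(F)(F)F)cc3Cl)CC2)nc2ccccc21`: 631 nM

Two compounds share a common core and differ only in the six-membered aromatic ring attached to the piperazine. In a functional assay on HEK293 cells for antagonist activity at D(4) dopamine receptor (Homo sapiens), read by FLIPR (a lower number here means a stronger inhibitor, a higher number a weaker inhibitor), compound 1 gives 398 nM, and compound 2 gives 631 nM. Compound 2 has the higher of the two numbers, but the gap to compound 1 lies within the usual scatter of this assay, so the two cannot be told apart on potency.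

Compound 3, `Cn1c(CN2CCN(c3ccc(C(F)(F)F)cn3)CC2)nc2ccccc21`, has not yet been measured. It derives from compound 2 by a single change: hydrogen in place of chloro on an aromatic carbon. The chloro group is lost and a hydrogen takes its place on the ring carbon; nothing else in the molecule moves.

Among the compounds with values here, no measured pair shows what this change does, so the expectation rests only on the two values above. Since compound 1 and compound 2 sit close together, the step of a 1.1-fold higher number from compound 2 to compound 3 (0.05 log units; within the scatter) is expected to be small, with no clear direction beyond the scatter. Compound 3 is therefore estimated at 700 nM, with a likely range from 250 nM to 2000 nM.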

Compound 3, inhibition constant: 1000 nM
Estimate against measurement, compound 3: 1.4-fold (0.15 log units) below; the measured number falls inside the stated range.
By their numbers in this assay, from the lowest: compounds 1, 2 and 3 (each within the scatter of the next, the first and the last beyond it).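

Chloro on this carbon, ortho to a large group and two atoms from the ring nitrogen, has now been exchanged directly for hydrogen, and in this assay this gives a 1.6-fold higher number from compound 2 to compound 3 (0.20 log units; within the scatter), so compound 2 and compound 3 cannot be told apart on potency. On these numbers, the chloro group is not needed for this level of activity, and the removal adds a further point of comparison: compound 1 at 398 nM and compound 3 at 1000 nM lie beyond the scatter of each other, although each lies within the scatter of compound 2. No measurement available here explains these values, so the data record only how the numbers compare.

As far as these compounds go, what a methyl group, a methoxy group or an amine on this same carbon would do remains open, including whether any of them would move the number beyond the scatter. From the compounds shown here alone, it is also open whether exchanging chloro for hydrogen would give a similar result on a ring without the ring nitrogen, or with the trifluoromethyl group replaced by a nitrile.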